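Series notes: from compound 3 to compound 4

The source may report more compounds than this note shows. Statements on the series, on what has been measured and on what is new or still open speak of the compounds shown alone.

Measured in a functional assay on MCF7 cells (Homo sapiens) for antiproliferative activity, read by MTT assay, with a stated time of 72 h; on this read-out lower numbers stand for stronger inhibition and higher numbers for weaker inhibition:
compound 1 `CN(Cc1ccc(-c2ccccc2)cc1)Cc1cn(C)c2ccc(CNc3ccc(F)cc3)cc12` gives 20200 nM
compound 2 `CN1CCN(Cc2cn(C)c3ccc(C(=O)Nc4ccc(F)cc4)cc23)CC1` gives 24700 nM
compound 3 `CN(Cc1ccc(-c2ccccc2)cc1)Cc1cn(C)c2ccc(C(=O)Nc3ccc(F)cc3)cc12` gives 54400 nM

Compound 3 stands highest of the three in this assay; compound 2 lies nearest to it, compound 1 furthest, both gaps beyond the scatter. Within the data shown here, the only comparison that holds a single change is a 2.7-fold higher number from compound 1 to compound 3 (0.43 log units; beyond the scatter), a modest step. Compound 2 and compound 3 share the (4-fluorophenyl)carbamoyl group and differ at the amine; their two values show compound 2 lower, beyond the scatter.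

Compound 4 `COc1cc(CN(C)Cc2cn(C)c3ccc(C(=O)Nc4ccc(F)cc4)cc23)cc(OC)c1OC` is not yet measured. It differs from compound 3 by 3,4,5-trimethoxyphenyl in place of 4-phenylphenyl on a saturated chain carbon bound to an amine nitrogen. Among the measured compounds shown here, no measured step touches this position: the one recorded step alters the group on the aromatic carbon, not the substituent on the amine. The pair compound 2 and compound 3 shows that a change at the amine can move the number beyond the scatter, but gives no direction for this particular group. The expected step is a 1.6-fold lower number from compound 3 to compound 4 (0.19 log units; within the scatter), within the scatter, with wide uncertainty. The estimate for compound 4 in this assay is 35000 nM, in the range 8000 nM to 120000 nM.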

Compound 4, half-maximal inhibitory concentration: 13200 nM
Compound 4: middle estimate off by 2.7-fold (0.42 log units), on the high side; the range from low to high includes it.
By their numbers in this assay, from the lowest: compounds 4, 1 and 2 (each within the scatter of the next); then compound 3.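

In this assay the substituent on the saturated chain carbon bound to an amine nitrogen now has a measured direction for one exchange: 3,4,5-trimethoxyphenyl in place of 4-phenylphenyl gives a 4.1-fold lower number from compound 3 to compound 4 (0.62 log units; beyond the scatter) and so lowers the number. The step comes with no change in heavy-atom count, while the entering group has one aromatic ring where the leaving group has two, and it has hydrogen-bond acceptors where the leaving group has none. Nothing at hand gives a cause for the step.

Going by these compounds, with a single pair at this position, it remains open whether the ring count or the methoxy groups go with the lower number. A plain phenyl or a 4-methoxyphenyl group in the same place would separate the two.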